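Nitro for methoxy on the aromatic carbon: compound 3

The compounds below may be only part of what the source reports. "The series", "measured", "known", "first", "only" and "open" are said of these compounds alone.

Compound 1 `CC1=CC[C@H](C(C)(C)NC(=S)N/N=C(\C)c2ccccc2)CC1` was tested in a functional assay on UACC-62 cells (Homo sapiens) for inhibition, read by sulforhodamine B assay, with a stated time of 48 h; on this read-out lower numbers stand for stronger inhibition of growth and higher numbers for weaker inhibition of growth; for compound 1 the result is only a limit, > 100000 nM. Compound 2 `COc1ccc(/C(C)=N/NC(=S)NC(C)(C)[C@H]2CC=C(C)CC2)cc1` likewise returns only a limit, > 100000 nM. For the measured compounds named here, the single step between them, a step that the two limits leave unreadable from compound 1 to compound 2, is therefore unreadable, since both values sit at the limit of > 100000 nM in this assay, at which 2 of the 2 values shown sit. Compound 3 `CC1=CC[C@H](C(C)(C)NC(=S)N/N=C(\C)c2ccc([N+](=O)[O-])cc2)CC1` differs from compound 2 by nitro in place of methoxy on an aromatic carbon. No readable measured step bears on this change, and both values shown sit at the same limit, so no step beyond the scatter is expected: a step that the limit leaves unreadable from compound 2 to compound 3. Compound 3 is expected at 150000 nM, within 30000 nM to 600000 nM, most likely again reported as a limit.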

Compound 3, concentration for total growth inhibition: 46800 nM
The estimate for compound 3 lay 3.2-fold (0.51 log units) above the measured number, and the stated range covers the measured number.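

In this assay, the aromatic carbon para to a large group now gives readable steps: nitro in place of methoxy gives an at least 2.1-fold lower number from compound 2 to compound 3 (0.32 log units; beyond the scatter), and nitro in place of hydrogen gives an at least 2.1-fold lower number from compound 1 to compound 3 (0.32 log units; beyond the scatter). The step between compound 1 and compound 2 cannot be read. Both new steps are bounds only, since each starts from a limit: the limit of > 100000 nM in this assay, at which 2 of the 3 values shown sit.

The compounds shown leave open whether an amine, a nitrile or a carboxylic acid on this aromatic carbon would also lower the number. On these data alone, the true size of both nitro steps also stays open.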